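The source may report more compounds than this note shows. Statements on the series, on what has been measured and on what is new or still open speak of the compounds shown alone.

The shared core of this small set is a five-membered ring bearing two nitrogen atoms, with an aryl group on the ring nitrogen and a second aryl group on the saturated ring carbon. Compound 1 `CC(C)(C)C1=NN(c2ccc(F)c(Cl)c2)C(c2ccc(O)cc2)C1` gives 900 nM in an assay on isolated protein for inhibition of protein kinase C zeta type (Homo sapiens), with a stated time of 4 min; a lower number here means a stronger inhibitor, a higher number a weaker inhibitor. Compound 2 `Oc1ccc(C2CC(c3ccccn3)=NN2c2cccc(Cl)c2)cc1` carries a pyridyl group where compound 1 has a tert-butyl group, and a different aryl group on the ring nitrogen; in this assay compound 2 gives 6200 nM. Compound 3 `CC(C)(C)C1=NN(c2ccc(Cl)cc2)C(c2ccc(Cl)cc2)C1` keeps the tert-butyl group and carries 4-chlorophenyl groups on both the ring nitrogen and the saturated ring carbon; in this assay compound 3 gives "not determined" (no result reported), so compound 3 stands nowhere on the numbers at hand.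

Compound 4 `CC(C)(C)C1=NN(c2ccc(Cl)cc2)C(c2cccc(O)c2)C1` differs from compound 3 by 3-hydroxyphenyl in place of 4-chlorophenyl on a saturated ring carbon. For the measured compounds named here, no measured pair shows this single change, so its size and direction cannot be read from the data. Compound 4 resembles compound 1 in carrying both the tert-butyl group and a hydroxyphenyl group on the saturated ring carbon, though the hydroxyl group and the aryl group on the ring nitrogen are not the same. Compound 4 is therefore expected to give about 1500 nM in this assay, with an estimated range from 400 nM to 6000 nM, because compound 1 gives 900 nM.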

Compound 4, half-maximal inhibitory concentration: 5300 nM
Estimate against measurement, compound 4: 3.5-fold (0.55 log units) below, and the stated range covers the measured number.
By their numbers in this assay, from the lowest: compound 1; then compounds 4 and 2 (each within the scatter of the next).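

In this assay, for the compounds shown here, compound 3 has no single number, so no step from it to compound 4 can be read. The compounds shown leave open how replacing 4-chlorophenyl with 3-hydroxyphenyl on the saturated ring carbon alone shifts the value. Nothing at hand offers an explanation for the result of compound 4.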